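This account rests on a few compounds, and the source may have more. Where it says the series, first, only, none or still open, it means among the compounds named here.

Working notes on the series. Compound 1 `COc1cc2c(cc1OC)C(=O)C(CC1CCN(C(=S)Nc3ccccc3)CC1)C2` gives 100 mg/kg in a functional assay on the whole organism (strain Swiss albino) with Mus musculus as the target, in the maximal electroshock model, with a stated time of 0.5 h; on this read-out higher numbers stand for an effect only at larger amounts of compound and lower numbers for an effect already at smaller amounts. Within the data shown here, compound 2 `COc1cc2c(cc1OC)C(=O)C(CC1CCN(C(=S)Nc3cccc([N+](=O)[O-])c3)CC1)C2` gives 300 mg/kg in this assay, the highest of the two numbers so far; the one step measured, a 3.0-fold higher number from compound 1 to compound 2 (0.48 log units; beyond the scatter), is the only one that bears on the change ahead. Compound 3 `COc1cc2c(cc1OC)C(=O)C(CC1CCN(C(=S)Nc3ccc(Cl)cc3)CC1)C2` differs from compound 2 by 4-chlorophenyl in place of 3-nitrophenyl on an amide-type nitrogen. Since the step from compound 1 to compound 2 showed nitro in place of hydrogen raising the number, its removal is expected to bring the number back toward compound 1, with the chloro substituent an open question; a step of a 2.0-fold lower number from compound 2 to compound 3 (0.30 log units; within the scatter) is expected. For compound 3 the estimate is 150 mg/kg, range 75 mg/kg to 300 mg/kg.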

Compound 3, minimum effective dose: 30 mg/kg
Compound 3: middle estimate off by 5.0-fold (0.70 log units), on the high side; measured number outside the range, below it.
By their numbers in this assay, from the lowest: compound 3; then compound 1; then compound 2.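

Substitution on this aromatic ring does not only raise the number: 4-chlorophenyl on the amide-type nitrogen gives a 3.3-fold lower number from compound 1 to compound 3 (0.52 log units; beyond the scatter), opposite in direction to the nitro step. The exchange of 3-nitrophenyl for 4-chlorophenyl spans a larger change, a 10-fold lower number from compound 2 to compound 3 (1.00 log units; beyond the scatter), so this place can move the number either way. Nothing shown gives a reason for this difference.

The compounds shown leave open whether the lower number belongs to chloro itself or to where it sits, as 3-chlorophenyl would tell. Also open, on these data alone, is whether 4-methoxyphenyl or 4-fluorophenyl would follow compound 3.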